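The source may hold more compounds than are shown below. What is called first, only, known or untested is meant among the compounds shown, and "the series" means these compounds.

In an assay on isolated protein (Oryctolagus cuniculus) with Thromboxane-A synthase (Homo sapiens) as the target, tested at 1 uM (a lower number here means less inhibition, a higher number more inhibition at the concentration tested (going by the name of the read-out)), three compounds have been measured so far:

compound 1 `CCCn1nc(-c2cccnc2)c2ccccc2c1=O` gives 86%
compound 2 `CCCCn1nc(-c2cccnc2)c2ccccc2c1=O` gives 91%
compound 3 `CCOC(=O)Cn1nc(-c2cccnc2)c2ccccc2c1=O` gives 28%

Compound 3 stands lowest of the three numbers. The two steps that lead to it are a number 58 percentage points lower from compound 1 to compound 3 (beyond the scatter) and a number 63 percentage points lower from compound 2 to compound 3 (beyond the scatter), both large, whereas a number 5 percentage points higher from compound 1 to compound 2 (within the scatter). The drops thus appear when an ethoxycarbonyl group enters on the chain carbon bound to the aromatic nitrogen, and a longer plain chain makes no difference beyond the scatter.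

Compound 4 `O=C(O)Cn1nc(-c2cccnc2)c2ccccc2c1=O` differs from compound 3 in one place: hydrogen in place of ethyl on an oxygen next to a carbonyl group, in other words ethoxycarbonyl becomes carboxy. Among the compounds with values here, none of the measured steps touches this oxygen; all three alter the chain on the aromatic nitrogen, so no step bears directly on the change, and the carbonyl that accompanied the large drops stays in place. The expected step is therefore small, a number 7 percentage points higher from compound 3 to compound 4 (within the scatter), with wide uncertainty. For compound 4 the estimate in this assay is 35%, expected to fall between 10% and 70%.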

Compound 4, a percentage reported as inhibition, at one concentration (the size of the read-out at that concentration, not a potency): 13%
Estimate against measurement, compound 4: 22 percentage points above; the range from low to high includes it.
By their numbers in this assay, from the lowest: compound 4; then compound 3; then compounds 1 and 2 (each within the scatter of the next).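

In this assay the ethyl on the oxygen next to a carbonyl group turns out to matter: with hydrogen in its place there is a number 15 percentage points lower from compound 3 to compound 4 (beyond the scatter) and the step is modest, so the loss seen with ethoxycarbonyl is not the floor for this chain. Against the plain chains, carboxy gives two large steps, a number 73 percentage points lower from compound 1 to compound 4 (beyond the scatter) and a number 78 percentage points lower from compound 2 to compound 4 (beyond the scatter) in turn, so both groups that carry a carbonyl stand far below the simple chains. Nothing measured here explains why these numbers fall. The compounds shown leave open whether the loss goes with the carbonyl itself, which a methoxyethyl chain without a carbonyl could test. They also leave open whether a primary amide in place of the carboxy would stand nearer compound 3 or compound 4.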